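The source may report more compounds than this note shows. Statements on the series, on what has been measured and on what is new or still open speak of the compounds shown alone.

Measured so far, all in an assay on isolated protein for inhibition of high affinity 3',5'-cyclic-AMP phosphodiesterase 7A (Homo sapiens), read by cAMP accumulation, with a stated time of 10 min; a lower number here means a stronger inhibitor, a higher number a weaker inhibitor:
- compound 1 `COc1nc2c(c(=O)n(C)c(=O)n2C)n1CC(=O)Nc1ccc(C(C)(C)C)cc1`: > 200000 nM, a limit of the assay, not a number.
- compound 2 `COc1nc2c(c(=O)n(C)c(=O)n2C)n1CC(=O)Nc1ccc(C(C)C)cc1`: > 200000 nM, again a limit.
- compound 3 `COc1nc2c(c(=O)n(C)c(=O)n2C)n1CCCC(=O)Nc1ccc(Cl)cc1`: > 200000 nM, again a limit.

Compound 1 therefore stands nowhere readable: its value in this assay is only the limit at which all three measured compounds sit (the limit of > 200000 nM in this assay, at which 3 of the 3 values shown sit). Within the data shown here, the one single-point step among them, from compound 1 to compound 2 a step that the two limits leave unreadable from compound 1 to compound 2, changes hydrogen for methyl on a saturated chain carbon bound to an aromatic carbon and two saturated chain carbons and cannot be read in size, because both ends are limits (the limit of > 200000 nM in this assay, at which 3 of the 3 values shown sit). Compound 3 differs from compound 1 in more than one place, so nothing is computed for that pair; both show only the limit.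

The compound not yet measured is compound 4 `CCOc1nc2c(c(=O)n(C)c(=O)n2C)n1CC(=O)Nc1ccc(C(C)(C)C)cc1`. It differs from compound 1 by methyl in place of hydrogen on a saturated chain carbon bound to an oxygen on an aromatic ring, that is methoxy to ethoxy on the shared core. Among the measured compounds shown here, no measured step bears on this change, and the only step measured is itself unreadable. With every value shown at the limit (the limit of > 200000 nM in this assay, at which 3 of the 3 values shown sit), the step from compound 1 to compound 4 is expected to be a number no higher from compound 1 to compound 4 (the limit leaves the size open), meaning no readable step. Compound 4 is accordingly expected to give about 200000 nM in this assay, within a range of 50000 nM to 600000 nM, with the outcome most likely reported again as a limit rather than as a number.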

Compound 4, half-maximal inhibitory concentration: > 200000 nM
Compound 4 ended at the assay's limit; the forecaster's own chance of this, stated with the estimate: 85%; the middle value lies on the limit itself.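

No step can be read from compound 1 to compound 4, because both values are limits and not numbers: the limit of > 200000 nM in this assay, at which 4 of the 4 values shown sit.

The compounds shown leave open what size the change from methoxy to ethoxy has in this assay, and which change on the shared core, if any, would give a readable number there.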